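From compound 2 to compound 3 at the assay limit

A few compounds are considered here, and "the series" means these few. Any claim that something is new, unique, unknown or untested is made for them only; others in the source may bear on it.

In an ADME assay on WI-38 cells (Homo sapiens) for inhibition, read by MTT assay, with a stated time of 72 h (a lower number here means a stronger inhibitor, a higher number a weaker inhibitor), the measured compounds are these
compound 1 `CC[C@H](C)[C@H](NC)C(=O)N1CCC[C@@H]1C(=O)N1C(=O)C=C(OC)[C@@H]1C(C)C` with > 50000 nM (a limit)
compound 2 `CC[C@H](C)[C@@H](C(=O)N1CCC[C@@H]1C(=O)N1C(=O)C=C(OC)[C@@H]1C(C)C)N(C)C(=O)[C@@H]1CCCN1` with > 50000 nM (a limit)

Compound 2 stands only at a limit and has no number: the position is the limit of > 50000 nM in this assay, at which 2 of the 2 values shown sit, and nothing finer can be read. Among the compounds with values here, compound 3 `CC[C@H](C)[C@@H](C(=O)N1CCC[C@@H]1C(=O)N1C(=O)C=C(OC)[C@@H]1C(C)C)N(C)C(=O)[C@@H]1CCCN1C(=O)[C@@H](NC)C(C)C` carries (2-methyl-1-(methylamino)propyl)carbonyl in place of hydrogen on an amine nitrogen in a ring (the one change). Within the data shown here, the only measured step bearing on this is a step that the two limits leave unreadable from compound 1 to compound 2 (there too a group replaced hydrogen on an amine nitrogen). It offers no size to carry over, so no step beyond the scatter and no direction is expected in this assay for this change. The estimated step is a number no higher from compound 2 to compound 3 (the limit leaves the size open) (an expectation only). For compound 3 the expected value is 50000 nM (estimated range 20000 nM to 100000 nM).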

Compound 3, half-maximal inhibitory concentration: > 50000 nM
Compound 3: no number, only a limit; the forecaster's own chance of this, stated with the estimate: 70%; the middle value sits exactly at the limit.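

Compound 3 stands only at a limit in this assay, and no step between compound 2 and compound 3 can be read: the limit of > 50000 nM in this assay, at which 3 of the 3 values shown sit.

The compounds shown leave open how far any of them lies past that limit, and whether any of these changes moves the value in this assay at all.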